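Fluorophenyl for dimethoxyphenyl on a chalcone biaryl core

This account rests on a few compounds, and the source may have more. Where it says the series, first, only, none or still open, it means among the compounds named here.

Of the compounds shown here, three have been tested in a functional assay on MCF7 cells (Homo sapiens) for antiproliferative activity, read by sulforhodamine B assay, with a stated time of 48 h; on this read-out higher numbers stand for weaker inhibition and lower numbers for stronger inhibition. Compound 1 `COc1ccc(/C=C/C(=O)c2ccccc2-c2ccc(OC)c(OC)c2)cc1OC` gives 4900 nM. Compound 2 `COc1ccc(OC)c(/C=C/C(=O)c2ccccc2-c2ccc(OC)c(OC)c2)c1` gives 3100 nM. Compound 3 `COc1ccc(/C=C/C(=O)c2ccccc2-c2ccc(F)cc2)cc1OC` gives 240 nM.

The cores of compound 1 and compound 2 differ as follows: 2,5-dimethoxyphenyl in place of 3,4-dimethoxyphenyl on a double-bonded chain carbon bound to a double-bonded chain carbon. This rearrangement gives a 1.6-fold lower number from compound 1 to compound 2 (0.20 log units; within the scatter), so the two values are not distinguished here.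

The change from compound 1 to compound 3 is 4-fluorophenyl in place of 3,4-dimethoxyphenyl on an aromatic carbon. It gives a 20-fold lower number from compound 1 to compound 3 (1.31 log units; beyond the scatter), the only clear separation within the measured set.

Compound 4 `COc1ccc(OC)c(/C=C/C(=O)c2ccccc2-c2ccc(F)cc2)c1` is not yet measured. It is made from compound 2 by the change (4-fluorophenyl in place of 3,4-dimethoxyphenyl on an aromatic carbon), which is the same change as that from compound 1 to compound 3, at a place described in the same words in both pairs. The change has been observed in one pair only, so its transfer onto the core of compound 2 rests on a single precedent.

In this assay compound 4 is expected to follow the step seen from compound 1 to compound 3, giving an expected 18-fold lower number from compound 2 to compound 4 (1.26 log units; beyond the scatter), because the same replacement produced a 20-fold lower number from compound 1 to compound 3 (1.31 log units; beyond the scatter) and the two cores sit close together, as a 1.6-fold lower number from compound 1 to compound 2 (0.20 log units; within the scatter) shows. Within the data shown here, compound 4 is therefore estimated at 170 nM, with a range of 60 nM to 500 nM allowing for the single precedent.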

Compound 4, half-maximal inhibitory concentration: 1700 nM
Compound 4: the middle estimate sits 10-fold (1.00 log units) below what was measured, and the stated range ends below it.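

In this assay, replacing 3,4-dimethoxyphenyl with 4-fluorophenyl does not carry the same step from one core to the other, and the two steps are clearly separated: the same change on two cores in this assay, a 20-fold lower number (1.31 log units; beyond the scatter) from compound 1 to compound 3 and a 1.8-fold lower number (0.26 log units; within the scatter) from compound 2 to compound 4, 11-fold (1.05 log units) apart, beyond the scatter of two such steps. On the second core the replacement gives a 1.8-fold lower number from compound 2 to compound 4 (0.26 log units; within the scatter), so in these two pairs the size of the step depends on the core it is made on, and closely similar starting values on two cores did not ensure that the step would transfer. Two pairs do not show why the steps differ, nor which of them is more typical of the series, and they give no basis for a general rule about this replacement.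

As far as these compounds go, it remains open whether the large step belongs specifically to the dimethoxyphenyl arrangement of compound 1 or also appears with other substituents on the phenyl ring of the chain, such as a single methoxy group or a hydroxyl. From the compounds shown here alone, it is also open whether another group in place of the 4-fluorophenyl, such as 4-chlorophenyl or a phenyl carrying an amine, would show the same dependence on the core.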